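Thiazole in Place of Allyloxy: Expected Cytotoxicity of Compound 4

This account rests on a few compounds, and the source may have more. Where it says the series, first, only, none or still open, it means among the compounds named here.

Measured so far in an ADME assay on PC-3 cells (Homo sapiens) for cytotoxicity, read by WST assay, tested at 100 uM; a lower number here means less inhibition, a higher number more inhibition at the concentration tested (going by the name of the read-out): compound 1 `O=C(Nc1cccc(OCCc2ccccn2)c1)C1CCCN(C(=O)c2cc(C(F)(F)F)cc(C(F)(F)F)c2)C1` gives 5%. Compound 2 `COC(=O)c1cccc(NC(=O)C2CCCN(C(=O)c3cc(C(F)(F)F)cc(C(F)(F)F)c3)C2)c1` gives 0%. Compound 3 `C=CCOc1cccc(NC(=O)C2CCCN(C(=O)c3cc(C(F)(F)F)cc(C(F)(F)F)c3)C2)c1` gives 0%.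

Compound 3 stands level with compound 2, together the lowest of the three numbers, and compound 1 sits only a number 5 percentage points lower from compound 1 to compound 3 (within the scatter) apart, so all three lie within the scatter of one another. Compound 4 `Cc1nc(-c2cccc(NC(=O)C3CCCN(C(=O)c4cc(C(F)(F)F)cc(C(F)(F)F)c4)C3)c2)cs1` carries the change (2-methyl-1,3-thiazol-4-yl in place of allyloxy on an aromatic carbon). The step that bears on it most directly is no change at the digits printed from compound 2 to compound 3 (within the scatter), where a different group at the same aromatic carbon left the number unchanged; the other two steps, a number 5 percentage points lower from compound 1 to compound 2 (within the scatter) and a number 5 percentage points lower from compound 1 to compound 3 (within the scatter), were also within the scatter. Compound 4 is therefore expected to show a number 3 percentage points higher from compound 3 to compound 4 (within the scatter), no shift beyond the scatter, with an estimated value of 3% in a range from 0% to 15%.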

Compound 4, a percentage reported as inhibition, at one concentration (the size of the read-out at that concentration, not a potency): 1%
Compound 4: the middle estimate sits 2 percentage points above what was measured; measured number inside the range.
By their numbers in this assay, from the lowest: compounds 2, 3, 4 and 1 (each within the scatter of the next).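

With 2-methyl-1,3-thiazol-4-yl, a five-membered aromatic ring, on this aromatic carbon, the number in this assay stays within the scatter of every earlier compound (a number 1 percentage points higher from compound 3 to compound 4 (within the scatter); a number 1 percentage points higher from compound 2 to compound 4 (within the scatter); a number 4 percentage points lower from compound 1 to compound 4 (within the scatter)). This position has therefore now carried an aromatic ring bound directly to it, as well as the earlier methoxycarbonyl, allyloxy and 2-(pyridin-2-yl)ethoxy groups, with no step beyond the scatter. No measurement available here accounts for this result. On these data alone, whether any group on this carbon can move the number beyond the scatter stays open, and an amine or a carboxylic acid there would be a further test.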